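The compounds below may be only part of what the source reports. "The series", "measured", "known", "first", "only" and "open" are said of these compounds alone.

Of the compounds shown here, three have been measured in a functional assay on MDA-MB-231 cells (Homo sapiens) for inhibition, read by MTT assay, with stated times of 18 h and 4 h; a lower number here means a stronger inhibitor, a higher number a weaker inhibitor. Compound 2 `CCCCCCCCCCOP(=O)(O)OCCSC(=S)N1CCN(C)CC1` gives 29000 nM there. Compound 1 `CCCCCCCCCCOP(=O)(O)OCCSC(=S)N1CCCCCC1` differs from compound 2 only by azepan-1-yl in place of 4-methylpiperazin-1-yl on a thiocarbonyl carbon, and in this assay compound 1 gives 11400 nM; the change made a step of a 2.5-fold lower number from compound 2 to compound 1 (0.41 log units; beyond the scatter). Compound 3 `CCCCCCCCOP(=O)(O)OCCSC(=S)N1CCN(C)CC1` carries a different core, differing from compound 2 by hydrogen in place of ethyl on a saturated chain carbon, eight bonds along the chain from an oxygen on an unsaturated carbon; in this assay compound 3 gives 58500 nM, a step of a 2.0-fold higher number from compound 2 to compound 3 (0.30 log units; within the scatter), so these two values cannot be told apart. Compound 3 has the highest of the three numbers, and only its gap to compound 1 lies beyond the scatter.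

Compound 4 `CCCCCCCCOP(=O)(O)OCCSC(=S)N1CCCCCC1` has not yet been measured. It differs from compound 3 by azepan-1-yl in place of 4-methylpiperazin-1-yl on a thiocarbonyl carbon, the same change, at the same place, as that from compound 2 to compound 1, now made on the core of compound 3. The step from compound 3 to compound 4 is expected to be about a 2.4-fold lower number from compound 3 to compound 4 (0.39 log units; beyond the scatter). This expectation rests on the single earlier observation of this change, a 2.5-fold lower number from compound 2 to compound 1 (0.41 log units; beyond the scatter), with wide uncertainty since it is seen only once. In this assay compound 4 is therefore estimated at 24000 nM, between 10000 nM and 55000 nM.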

Compound 4, half-maximal inhibitory concentration: 27000 nM
Beside the measured number, compound 4's estimate is 1.1-fold (0.05 log units) below it, and the stated range covers the measured number.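

In this assay, azepan-1-yl in place of 4-methylpiperazin-1-yl on the thiocarbonyl carbon gives a 2.2-fold lower number from compound 3 to compound 4 (0.34 log units; beyond the scatter), so this change carries over to the core of compound 3 at much the same size as on the earlier core: the same change on two cores in this assay, a 2.5-fold lower number (0.41 log units; beyond the scatter) from compound 2 to compound 1 and a 2.2-fold lower number (0.34 log units; beyond the scatter) from compound 3 to compound 4, 1.2-fold (0.07 log units) apart, within the scatter of two such steps. The chain change seen on the other side of the same four compounds, hydrogen in place of ethyl, gives a 2.4-fold higher number from compound 1 to compound 4 (0.37 log units; beyond the scatter), and it too is the same on both ring-bearing partners within the scatter: the same change on two cores in this assay, a 2.0-fold higher number (0.30 log units; within the scatter) from compound 2 to compound 3 and a 2.4-fold higher number (0.37 log units; beyond the scatter) from compound 1 to compound 4, 1.2-fold (0.07 log units) apart, within the scatter of two such steps. Among these compounds, this shows that the two changes behave independently of each other across these four compounds, but it rests on only two cores and one pair per core in a single assay, and it does not show why the numbers move or that the transfer extends beyond these compounds.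

The compounds shown leave open whether the step would keep its size on a longer chain. They also leave open whether a morpholin-4-yl group on the thiocarbonyl carbon would follow azepan-1-yl or 4-methylpiperazin-1-yl.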